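This account rests on a few compounds, and the source may have more. Where it says the series, first, only, none or still open, it means among the compounds named here.

Compound 1 `CN(C)c1ccc(C2CC(c3ccc(-n4cncn4)cc3)=NN2C(=O)c2cc(Cl)cc(Cl)c2)cc1`: 8.4%
Compound 2 `CN(C)c1ccc(C2CC(c3ccc(-n4cncn4)cc3)=NN2C(=O)c2ccc(C(F)(F)F)cc2)cc1`: 11.5%
Compound 3 `CN(C)c1ccc(C2CC(c3ccc(-n4ccnc4)cc3)=NN2C(=O)c2cc(Cl)cc(Cl)c2)cc1`: 58.7%

All three were tested in a functional assay on NCI-H1975 cells (Homo sapiens) for inhibition, read by sulforhodamine B assay, tested at 10 uM; a higher number here means more inhibition at the concentration tested (going by the name of the read-out), a lower number less inhibition. Compound 2 differs from compound 1 by 4-(trifluoromethyl)phenyl in place of 3,5-dichlorophenyl on a carbonyl carbon, and this gave a number 3.1 percentage points higher from compound 1 to compound 2 (within the scatter). Compound 3 differs from compound 1 by 1H-imidazol-1-yl in place of 1H-1,2,4-triazol-1-yl on an aromatic carbon, and this gave a number 50.3 percentage points higher from compound 1 to compound 3 (beyond the scatter). Compound 3 therefore stands highest of the three measured compounds, with both of its steps to the others beyond the scatter.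

Compound 4 `CN(C)c1ccc(C2CC(c3ccc(-n4ccnc4)cc3)=NN2C(=O)c2ccc(C(F)(F)F)cc2)cc1` has not yet been measured in this assay. It differs from compound 3 by 4-(trifluoromethyl)phenyl in place of 3,5-dichlorophenyl on a carbonyl carbon. The place of this change is the same, word for word, as the place of the change from compound 1 to compound 2, so it is the same change, here made on the core of compound 3. Because that earlier change gave a number 3.1 percentage points higher from compound 1 to compound 2 (within the scatter), the step is expected to be of a similar, small size, a number 2.3 percentage points higher from compound 3 to compound 4 (within the scatter). On this basis compound 4 is estimated to give 61% in this assay, with the likely range from 42% to 78%. This rests on a single earlier instance of the change, so the range is kept wide.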

Compound 4, a percentage reported as inhibition, at one concentration (the size of the read-out at that concentration, not a potency): 15.9%
Beside the measured number, compound 4's estimate is 45.1 percentage points above it; measured number below the stated range.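

With 1H-imidazol-1-yl on the shared core, putting 4-(trifluoromethyl)phenyl in place of 3,5-dichlorophenyl gave a number 42.8 percentage points lower from compound 3 to compound 4 (beyond the scatter) in this assay, so the change did not carry over from the core of compound 1: the same change on two cores in this assay, a number 3.1 percentage points higher (within the scatter) from compound 1 to compound 2 and a number 42.8 percentage points lower (beyond the scatter) from compound 3 to compound 4, 45.9 percentage points apart, beyond the scatter of two such steps. Read the other way, 1H-imidazol-1-yl in place of 1H-1,2,4-triazol-1-yl gave only a number 4.4 percentage points higher from compound 2 to compound 4 (within the scatter), so that change did not carry over either: the same change on two cores in this assay, a number 50.3 percentage points higher (beyond the scatter) from compound 1 to compound 3 and a number 4.4 percentage points higher (within the scatter) from compound 2 to compound 4, 45.9 percentage points apart, beyond the scatter of two such steps. The two changes therefore cannot be treated as adding up in this series, as the high number of compound 3 appears only with this pairing of groups, but four compounds at a single concentration do not show why this is so or how far it extends.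

From the compounds shown here alone, it remains open whether the high number needs the 3,5-dichlorophenyl group itself or would also appear with a plain phenyl or a 3,5-difluorophenyl on the carbonyl carbon. Going by these compounds, it is also open whether a pyridine ring in place of 1H-imidazol-1-yl would behave in the same way.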